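Pyrazolyl replacement at the aryl position of compound 3

The source may report more compounds than this note shows. Statements on the series, on what has been measured and on what is new or still open speak of the compounds shown alone.

Three compounds of the series share one core and differ only in the aromatic group attached to the five-membered ring bearing the carboxy group. Compound 1 `COc1ccc(C)cc1-c1c(C)nn(-c2nc(-c3ccc(Cl)c(Cl)c3)c(SC(C)C)s2)c1C(=O)O` gives 9500 nM in a functional assay on BJAB cells (Homo sapiens) for antiproliferative activity, with a stated time of 4 days; on this read-out higher numbers stand for an effect only at larger amounts of compound and lower numbers for an effect already at smaller amounts. Compound 2 `Cc1ccccc1-c1c(C)nn(-c2nc(-c3ccc(Cl)c(Cl)c3)c(SC(C)C)s2)c1C(=O)O` gives 5500 nM in this assay, and compound 3 `Cc1nn(-c2nc(-c3ccc(Cl)c(Cl)c3)c(SC(C)C)s2)c(C(=O)O)c1-c1cccc(Cl)c1C` gives 5100 nM. Compound 3 holds the lowest of the three numbers, but the steps to it are a 1.9-fold lower number from compound 1 to compound 3 (0.27 log units; within the scatter) and a 1.1-fold lower number from compound 2 to compound 3 (0.03 log units; within the scatter), so it is not separated from the others beyond the scatter; likewise a 1.7-fold lower number from compound 1 to compound 2 (0.24 log units; within the scatter).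

The next compound, compound 4 `Cc1nn(-c2nc(-c3ccc(Cl)c(Cl)c3)c(SC(C)C)s2)c(C(=O)O)c1-c1cnn(C)c1`, alters the same position: 1-methyl-1H-pyrazol-4-yl in place of 3-chloro-2-methylphenyl on an aromatic carbon. Among the compounds with values here, no measured step swaps a six-membered aromatic ring of carbon only for a five-membered aromatic ring with hetero atoms, so the three measured steps bear on it only as a sign that this position tolerates variation of the aryl group without a shift beyond the scatter. Direction and size of the change cannot be read from them.

For compound 4 the number is therefore expected near the measured range, with a step estimated as a 1.5-fold higher number from compound 3 to compound 4 (0.17 log units; within the scatter) from compound 3. The expected value for compound 4 in this assay is 7500 nM, with a range of 2500 nM to 25000 nM.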

Compound 4, half-maximal effective concentration: 6800 nM
Compound 4: middle estimate off by 1.1-fold (0.04 log units), on the high side, and the stated range covers the measured number.
By their numbers in this assay, from the lowest: compounds 3, 2, 4 and 1 (each within the scatter of the next).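

Putting 1-methyl-1H-pyrazol-4-yl at this position keeps the number in this assay within the scatter of all three earlier compounds: a 1.3-fold higher number from compound 3 to compound 4 (0.12 log units; within the scatter) and a 1.2-fold higher number from compound 2 to compound 4 (0.09 log units; within the scatter) and a 1.4-fold lower number from compound 1 to compound 4 (0.15 log units; within the scatter) are all small steps. Within the data shown here, the earlier compounds varied only groups with one six-membered aromatic ring of carbon only, so this is the first sign that the position also accepts a five-membered aromatic ring with 2 hetero atoms, and a group with 2 hydrogen-bond acceptors in place of one with none, without a shift beyond the scatter. No supporting data bear on why the read-out stays this flat across the change.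

On these data alone, it remains open whether a non-aromatic group at this position, such as a morpholine ring or a simple amine, stays within the same range or gives a step beyond the scatter. Also open, as far as these compounds go, is what the methyl group on the pyrazole contributes, which a plain 1H-pyrazol-4-yl group would test against compound 4 in a single-place comparison.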